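The compounds below may be only part of what the source reports. "The series", "measured", "known", "first", "only" and "open" are said of these compounds alone.

Measured so far: compound 1 `CCCCOC(=O)Nc1ccc([Se]C#N)cc1` gives 6.6% in a physicochemical assay, with a stated time of 180 min, tested at 0.5 mg/mL; on this read-out lower numbers stand for less inhibition and higher numbers for more inhibition at the one concentration tested (going by the name of the read-out); compound 2 `CCOC(=O)Nc1ccc([Se]C#N)cc1` gives 37% in this assay.

Compound 2 stands highest of the two numbers; its nearest neighbour is compound 1, reached by the step of a number 30.4 percentage points higher from compound 1 to compound 2 (beyond the scatter).

Compound 3 `N#C[Se]c1ccc(NC(=O)Oc2ccccc2)cc1` differs from compound 2 by phenyl in place of ethyl on an oxygen next to a carbonyl group. Within the data shown here, the only measured step, a number 30.4 percentage points higher from compound 1 to compound 2 (beyond the scatter), concerns a saturated chain and bears only loosely on phenyl entering on an oxygen next to a carbonyl group, so a step beyond the scatter in either direction is possible. The estimate for compound 3 is 25% (range 5% to 50%), an expected step of a number 12 percentage points lower from compound 2 to compound 3 (beyond the scatter).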

Compound 3, a percentage reported as inhibition, at one concentration (the size of the read-out at that concentration, not a potency): 19.3%
Compound 3: the middle estimate sits 5.7 percentage points above what was measured, within the range that was stated.
By their numbers in this assay, from the lowest: compound 1; then compound 3; then compound 2.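

In this assay, phenyl in place of ethyl on an oxygen next to a carbonyl group gives a number 17.7 percentage points lower from compound 2 to compound 3 (beyond the scatter) while phenyl in place of butyl at the same place gives a number 12.7 percentage points higher from compound 1 to compound 3 (beyond the scatter) and so the direction of the change depends on which chain leaves. Phenyl therefore sits between the two saturated chains, and this place shows no single ring-against-chain trend across compound 1, compound 2 and compound 3. No measurement at hand accounts for this order.

Open, going by these compounds, is how methyl, a benzyl group or a phenyl carrying an amine would read on this oxygen. Also open, on these data alone, is whether the same order holds in any other read-out.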